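Series notes: sulfonyl aryl variation and tissue distribution

The source may report more compounds than this note shows. Statements on the series, on what has been measured and on what is new or still open speak of the compounds shown alone.

For the measured compounds named here, compound 1 `N#Cc1ccc(O[C@H]2CN(S(=O)(=O)c3ccc(C(F)(F)F)cc3)C[C@@]2(O)CO)cc1F` stands highest of the two numbers so far in an ADME assay on the whole organism (Rattus norvegicus, strain Sprague-Dawley) for pharmacokinetics, read by LC-MS, with a stated time of 30 min; on this read-out lower numbers stand for narrower distribution and higher numbers for wider distribution into tissues; in this assay compound 1 gives 180 L/kg. Its nearest neighbour, compound 2 `N#Cc1ccc(O[C@H]2CN(S(=O)(=O)c3ccc(C(F)(F)F)nc3)C[C@@]2(O)CO)cc1F`, carries the 6-(trifluoromethyl)pyridin-3-yl in place of the 4-(trifluoromethyl)phenyl on the sulfonyl sulfur, and in this assay compound 2 gives 28 L/kg, which is a 6.4-fold lower number from compound 1 to compound 2 (0.81 log units; beyond the scatter).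

The next step goes from compound 1 to compound 3 `N#Cc1ccc(O[C@H]2CN(S(=O)(=O)c3ccc(C(F)(F)F)cc3C#N)C[C@@]2(O)CO)cc1F`, which is not yet measured in this assay. The change is cyano in place of hydrogen on an aromatic carbon, sitting on an aromatic carbon of the six-membered aromatic ring of carbon only, ortho to a large group and meta to the trifluoromethyl group.

Going by the values given here, no measured step introduces a cyano on this ring; the only step that bears on the question, loosely, is a 6.4-fold lower number from compound 1 to compound 2 (0.81 log units; beyond the scatter), where one heavy atom of the ring itself changed. That step was modest and beyond the scatter. A substituent added to the same ring is a different kind of change, so the expectation is for a smaller move, downward if anything, and possibly within the scatter.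

Compound 3 is therefore estimated in this assay at 90 L/kg, with a range from 30 L/kg to 270 L/kg, meaning an expected step of a 2.0-fold lower number from compound 1 to compound 3 (0.30 log units; within the scatter).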

Compound 3, volume of distribution at steady state: 73 L/kg
Compound 3: middle estimate off by 1.2-fold (0.09 log units), on the high side; low and high end bracket the measured number.
By their numbers in this assay, from the lowest: compound 2; then compound 3; then compound 1.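

In this assay, cyano in place of hydrogen on an aromatic carbon, ortho to a large group and meta to a trifluoromethyl group, gives a 2.5-fold lower number from compound 1 to compound 3 (0.39 log units; beyond the scatter) and so lies beyond the scatter; this position therefore responds to a substituent added to the ring, whereas the earlier pair showed only a change of an atom within the ring. Together with a 6.4-fold lower number from compound 1 to compound 2 (0.81 log units; beyond the scatter) as the other step, both single changes shown from compound 1 lead to a lower number, leaving compound 1 the highest of the three in this small set. Nothing available accounts for the move seen with the cyano group.

The compounds shown leave open whether this step is specific to cyano or would also appear with another group on the same aromatic carbon, such as a methyl, a methoxy or a primary amine. They also leave open whether cyano on the corresponding ring of compound 2 would lower the number further or leave it unchanged.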